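The source may hold more compounds than are shown below. What is called first, only, known or untested is meant among the compounds shown, and "the series" means these compounds.

Compound 2 `CC1CCCN(CCCOc2ccc(-c3ccc(C#N)cc3)cc2)C1` was tested in an assay on isolated protein for binding affinity to histamine H2 receptor (Homo sapiens) (on this read-out lower numbers stand for stronger inhibition and higher numbers for weaker inhibition), where compound 2 gives 11700 nM. Among the two measured compounds it carries the highest number, and its only neighbour is compound 1 `C[C@@H]1CC[C@@H](C)N1CCCOc1ccc(-c2ccc(C#N)cc2)cc1`, which in this assay gives 9120 nM. The step of a 1.3-fold higher number from compound 1 to compound 2 (0.11 log units; within the scatter) means the two compounds cannot be told apart on this read-out.

The move to compound 3 `N#Cc1ccc(-c2ccc(OCCCN3CCNCC3)cc2)cc1` is piperazin-1-yl in place of 3-methylpiperidin-1-yl on a saturated chain carbon, three bonds along the chain from an oxygen on an aromatic ring. Among the compounds with values here, only one measured step bears on a change at this place: the exchange of 2,5-dimethylpyrrolidin-1-yl for 3-methylpiperidin-1-yl, read as a 1.3-fold higher number from compound 1 to compound 2 (0.11 log units; within the scatter), which lay within the scatter. That step swapped one carbon-only ring amine for another, whereas the new change brings in piperazin-1-yl, so it offers only loose guidance. With nothing in the measured set pointing to a large shift, the expectation for compound 3 is a step of a 1.7-fold higher number from compound 2 to compound 3 (0.23 log units; within the scatter), leaning toward a higher number but not confidently beyond the scatter. Compound 3 is therefore estimated at 20000 nM, with a range from 6000 nM to 60000 nM.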

Compound 3, inhibition constant: 22900 nM
Estimate against measurement, compound 3: 1.1-fold (0.06 log units) below, within the range that was stated.
By their numbers in this assay, from the lowest: compounds 1, 2 and 3 (each within the scatter of the next, the first and the last beyond it).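

In this assay, the exchange of 3-methylpiperidin-1-yl for piperazin-1-yl, which brings a second ring nitrogen and a hydrogen-bond donor to the end of the chain, shows as a 2.0-fold higher number from compound 2 to compound 3 (0.29 log units; within the scatter) and so cannot be told apart on this read-out. Within the data shown here, measured against the 2,5-dimethylpyrrolidin-1-yl group, piperazin-1-yl gives a 2.5-fold higher number from compound 1 to compound 3 (0.40 log units; beyond the scatter) and thereby provides the first step in this small set that clears the scatter, although only modestly. This position has therefore now carried three different ring amines without any large shift in the number, but nothing available accounts for the modest separation of compound 1 and compound 3.

From the compounds shown here alone, it remains open whether an open-chain amine such as diethylamino, or a piperazine carrying a group on its second nitrogen such as 4-methylpiperazin-1-yl, would stay in the same range as these three ring amines. Also open, going by these compounds, is what a longer chain between the aromatic oxygen and the ring amine would do to the number, since all three compounds share the same chain.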